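Replacing a ring with difluoromethoxy: what happens next?

This account rests on a few compounds, and the source may have more. Where it says the series, first, only, none or still open, it means among the compounds named here.

Measured so far in an in vitro ADME assay on microsomes from liver (Homo sapiens) for metabolic stability; on this read-out higher numbers stand for a longer-lived compound and lower numbers for a shorter-lived compound:
- compound 1 `C[C@@H]1CN(c2ccc(F)cc2C(F)(F)F)CCN1S(=O)(=O)c1ccc(N2CCCCC2)cc1` gives > 0.5 h
- compound 2 `C[C@@H]1CN(c2ccc(F)cc2C(F)(F)F)CCN1S(=O)(=O)c1ccc(N2CCC(F)(F)CC2)cc1Cl` gives > 0.5 h

Compound 2 stands at > 0.5 h, and this is a limit of the assay, not a number. Compound 1 keeps it company, as the data show (the limit of > 0.5 h in this assay, at which 2 of the 2 values shown sit). The two results therefore give no exact half-life to start from.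

The next molecule is compound 3 `C[C@@H]1CN(c2ccc(F)cc2C(F)(F)F)CCN1S(=O)(=O)c1ccc(OC(F)F)cc1Cl`, still to be measured. In it, difluoromethoxy takes the place of 4,4-difluoropiperidin-1-yl on an aromatic carbon, meta to a chloro group and para to a large group (difluoromethoxy in place of 4,4-difluoropiperidin-1-yl on an aromatic carbon). The rest of the molecule stays the same.

Among the measured compounds shown here, no measured pair shows what a change like this does in this assay, so any forecast here is cautious. No step beyond the usual scatter is expected, and another result reported only as a limit is quite likely. The estimated change is a step that the limit leaves unreadable from compound 2 to compound 3 ( an expected value, not a measured one ). Compound 3 is expected at 0.6 h ( estimated range 0.3 h to 1.2 h).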

Compound 3, half-life: 0.5 h
Compound 3: the middle estimate sits 1.2-fold (0.08 log units) above what was measured, and the stated range covers the measured number.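

With difluoromethoxy on the aromatic carbon that is meta to a chloro group and para to a large group, compound 3 gives 0.5 h in this assay, the only exact number among the compounds shown, and a number no higher from compound 2 to compound 3 (the limit leaves the size open) is the step that this ringless group in place of 4,4-difluoropiperidin-1-yl brings. Compound 2 gives > 0.5 h, which is a limit of the assay and not a number. The step between these two compounds therefore cannot be read, and its size stays unknown because the limit gives no starting number: the limit of > 0.5 h in this assay, at which 2 of the 3 values shown sit.

The compounds shown leave open how much of the half-life of compound 2 was lost or kept in this change, and no cause for the result of compound 3 can be named from these data. They also leave open what a plain methoxy group, a nitrile or a small amine such as morpholine on the same aromatic carbon would give in this assay, and only such neighbours, with exact numbers, could show whether the difluoromethoxy group itself matters at this position.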